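The source may hold more compounds than are shown below. What is called first, only, known or untested is meant among the compounds shown, and "the series" means these compounds.

Measured compounds in the series:

- compound 1 `Nc1ccc(-c2nnc(SC3=CS(=O)(=O)c4ccccc43)o2)cc1`: 4000 nM
- compound 2 `Cc1ccc(-c2nnc(SC3=CS(=O)(=O)c4ccccc43)o2)cc1`: 3000 nM
- compound 3 `COc1cccc(-c2nnc(SC3=CS(=O)(=O)c4ccccc43)o2)c1`: 3000 nM

All three numbers come from an ADME assay on HEK293 cells (Homo sapiens) for cytotoxicity, read by fluorescence and resazurin assay, with a stated time of 24 h; on this read-out lower numbers stand for higher toxicity in this test and higher numbers for lower toxicity in this test. Compound 3 sits level with compound 2 at the digits given, the two together the lowest of the three numbers; a 1.3-fold lower number from compound 1 to compound 3 (0.12 log units; within the scatter) and no change at the digits printed from compound 2 to compound 3 (within the scatter) both stay within the scatter, as does a 1.3-fold lower number from compound 1 to compound 2 (0.12 log units; within the scatter). The substituent changes made so far on the shared core have left the read-out essentially unmoved.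

Compound 4 `COc1ccccc1-c1nnc(SC2=CS(=O)(=O)c3ccccc32)o1` differs from compound 3 by 2-methoxyphenyl in place of 3-methoxyphenyl on an aromatic carbon. Among the compounds with values here, no measured step relocates a methoxy group on the phenyl ring; the nearest comparisons are no change at the digits printed from compound 2 to compound 3 (within the scatter) and a 1.3-fold lower number from compound 1 to compound 3 (0.12 log units; within the scatter), both within the scatter. On that basis no step beyond the scatter is expected in this assay for compound 4, and the expected step from compound 3 is no change at the digits printed from compound 3 to compound 4 (within the scatter). Compound 4 is therefore estimated at 3000 nM, with a range from 1500 nM to 6000 nM.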

Compound 4, half-maximal cytotoxic concentration: 3000 nM
Compound 4: middle estimate and measured number agree at the digits printed, and the stated range covers the measured number.
By their numbers in this assay, from the lowest: compounds 2, 3, 4 and 1 (each within the scatter of the next).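

In this assay, within the data shown here, 2-methoxyphenyl in place of 3-methoxyphenyl on the same aromatic carbon gives no change at the digits printed from compound 3 to compound 4 (within the scatter), the only step here that relocates a methoxy group on the phenyl ring, and it stays within the scatter. The comparisons with the other two compounds, no change at the digits printed from compound 2 to compound 4 (within the scatter) and a 1.3-fold lower number from compound 1 to compound 4 (0.12 log units; within the scatter), also stay within the scatter, so the read-out does not separate the four aryl groups shown. No evidence is available to explain this flat result.

Going by these compounds, whether a carboxylic acid, a dimethylamino group or a longer alkyl chain on the phenyl ring would produce a step beyond the scatter remains open. So does the effect on this read-out of changing the shared core itself rather than its aryl group.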